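A few compounds are considered here, and "the series" means these few. Any claim that something is new, unique, unknown or untested is made for them only; others in the source may bear on it.

In a functional assay on MV4-11 cells (Homo sapiens) for inhibition, read by resazurin assay, with a stated time of 72 h (a lower number here means a stronger inhibitor of growth, a higher number a weaker inhibitor of growth), compound 1 `Cc1ccc(-c2cncc(Cl)c2N2CCC3(CCNC3=O)CC2)o1` gives 4950 nM and compound 2 `O=Cc1ccc(-c2cncc(Cl)c2N2CCC3(CCNC3=O)CC2)s1` gives 750 nM, the lower of the two numbers. Compound 3 `O=Cc1sccc1-c1cncc(Cl)c1N1CCC2(CCNC2=O)CC1` has the same atoms as compound 2, joined differently: 2-formylthiophen-3-yl in place of 5-formylthiophen-2-yl on an aromatic carbon. Within the data shown here, only one measured step bears on this change, a 6.6-fold lower number from compound 1 to compound 2 (0.82 log units; beyond the scatter), and it replaced the whole group rather than rearranging it. It therefore gives a rough size but no firm direction. A somewhat smaller move toward a higher number is expected, an estimated 2.4-fold higher number from compound 2 to compound 3 (0.38 log units; beyond the scatter). For compound 3 the expected value is 1800 nM, with an estimated range of 500 nM to 6000 nM.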

Compound 3, concentration for 50% growth inhibition: 28700 nM
The estimate for compound 3 lay 16-fold (1.20 log units) below the measured number; the whole stated range lies below it.
By their numbers in this assay, from the lowest: compound 2; then compound 1; then compound 3.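

In this assay, rearranging the same atoms, with nothing gained or lost, moves the number much further than the earlier replacement of a whole group did: a 38-fold higher number from compound 2 to compound 3 (1.58 log units; beyond the scatter). The arrangement of the thiophene and its formyl group on this aromatic carbon therefore matters in its own right, and 2-formylthiophen-3-yl also falls behind 5-methylfuran-2-yl: a 5.8-fold higher number from compound 1 to compound 3 (0.76 log units; beyond the scatter). Nothing measured here gives a reason for this loss. The compounds shown leave open whether the formyl group itself is needed on 5-formylthiophen-2-yl. A hydroxymethyl group or a carboxylic acid in its place would test this.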